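The source may report more compounds than this note shows. Statements on the series, on what has been measured and on what is new or still open speak of the compounds shown alone.

Compound 1 `CCSc1ccc(C2C(Oc3ccccc3)C(=O)N2c2cc(OC)c(OC)c(OC)c2)cc1` gives, in a functional assay on MCF7 cells (Homo sapiens) for inhibition, read by resazurin assay, with a stated time of 72 h (a lower number here means a stronger inhibitor, a higher number a weaker inhibitor), 210 nM.
Compound 2 `CCSc1ccc(C2C(O)C(=O)N2c2cc(OC)c(OC)c(OC)c2)cc1` gives, in this assay, 6 nM.
Compound 3 `CCOc1ccc(C2C(O)C(=O)N2c2cc(OC)c(OC)c(OC)c2)cc1` gives, in this assay, 7 nM.

Compounds 2 and 3 share a core and differ only in one group: ethoxy in place of ethylsulfanyl on an aromatic carbon. The step between them, a 1.2-fold higher number from compound 2 to compound 3 (0.07 log units; within the scatter), is small. Compound 1 arises from compound 2 by a single change, (phenyl in place of hydrogen on an oxygen on a saturated carbon), and this made a large step, a 35-fold higher number from compound 2 to compound 1 (1.54 log units; beyond the scatter).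

Compound 4 `CCOc1ccc(C2C(Oc3ccccc3)C(=O)N2c2cc(OC)c(OC)c(OC)c2)cc1` is not yet measured. It arises from compound 3 by the same change, (phenyl in place of hydrogen on an oxygen on a saturated carbon), at the same place. Because the same change gave a 35-fold higher number from compound 2 to compound 1 (1.54 log units; beyond the scatter), a step of similar size is expected in this assay for compound 4, namely a 33-fold higher number from compound 3 to compound 4 (1.52 log units; beyond the scatter). On that basis compound 4 is estimated at 230 nM, most likely between 90 nM and 600 nM.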

Compound 4, half-maximal inhibitory concentration: 69 nM
Compound 4: middle estimate off by 3.3-fold (0.52 log units), on the high side; measured number outside the range, below it.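

Replacing hydroxy with phenoxy again gave a weaker inhibitor in this assay, with a 9.9-fold higher number from compound 3 to compound 4 (0.99 log units; beyond the scatter), so the direction carried over from one core to the other, but the size did not: the same change on two cores in this assay, a 35-fold higher number (1.54 log units; beyond the scatter) from compound 2 to compound 1 and a 9.9-fold higher number (0.99 log units; beyond the scatter) from compound 3 to compound 4, 3.6-fold (0.55 log units) apart, beyond the scatter of two such steps

Read the other way, ethoxy in place of ethylsulfanyl gave a 3.0-fold lower number from compound 1 to compound 4 (0.48 log units; beyond the scatter), so the two changes do not simply add up: the same change on two cores in this assay, a 1.2-fold higher number (0.07 log units; within the scatter) from compound 2 to compound 3 and a 3.0-fold lower number (0.48 log units; beyond the scatter) from compound 1 to compound 4, 3.6-fold (0.55 log units) apart, beyond the scatter of two such steps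

This one pair of cores shows that the size of the step can differ with the group elsewhere on the molecule, but it does not show why, or what the step would be on any further core.

Still open, as far as these compounds go, is whether a methyl or benzyl on that oxygen would behave like phenyl. Also open, from the compounds shown here alone, is whether a longer chain, such as propoxy, in place of ethoxy would change the size of the step.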